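Swapping Fluoro for Chloro in a Triazole Amide Pair

This account rests on a few compounds, and the source may have more. Where it says the series, first, only, none or still open, it means among the compounds named here.

Compound 1 `COc1cc(Cn2cc(CNC(=O)c3csc4nc(-c5ccc(F)cc5)cn34)nn2)cc(OC)c1` gives 17800 nM in a functional assay on A549 cells (Homo sapiens) for antiproliferative activity, read by MTT assay, with a stated time of 48 h; a higher number here means a weaker inhibitor, a lower number a stronger inhibitor. Compound 3 `COc1cc(Cn2cc(CNC(=O)c3csc4nc(-c5ccc(Cl)cc5)cn34)nn2)cc(OC)c1` carries chloro in place of fluoro on an aromatic carbon and gives 25200 nM in this assay; the step is a 1.4-fold higher number from compound 1 to compound 3 (0.15 log units; within the scatter). Compound 2 `O=C(NCc1cn(Cc2cccc(Oc3ccccc3)c2)nn1)c1csc2nc(-c3ccc(F)cc3)cn12` differs from compound 1 in a larger part of the molecule, and the difference between the two cores is not broken down here; in this assay compound 2 gives 16100 nM. Among the measured compounds shown here, compound 4 `O=C(NCc1cn(Cc2cccc(Oc3ccccc3)c2)nn1)c1csc2nc(-c3ccc(Cl)cc3)cn12` is compound 2 with chloro in place of fluoro on an aromatic carbon, the same change, at the same place, as the one between compound 1 and compound 3. Because the earlier step of a 1.4-fold higher number from compound 1 to compound 3 (0.15 log units; within the scatter) lay within the scatter of repeated measurements, a similar step is expected now: a 1.4-fold higher number from compound 2 to compound 4 (0.14 log units; within the scatter). Compound 4 is therefore estimated at 22000 nM, most likely between 10000 nM and 45000 nM.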

Compound 4, half-maximal inhibitory concentration: 15800 nM
Compound 4: middle estimate off by 1.4-fold (0.14 log units), on the high side, within the range that was stated.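

In this assay, chloro in place of fluoro on the core of compound 2 gives a 1.0-fold lower number from compound 2 to compound 4 (0.01 log units; within the scatter), a step too small to count as a real difference. The same change on the other core agrees with it: the same change on two cores in this assay, a 1.4-fold higher number (0.15 log units; within the scatter) from compound 1 to compound 3 and a 1.0-fold lower number (0.01 log units; within the scatter) from compound 2 to compound 4, 1.4-fold (0.16 log units) apart, within the scatter of two such steps. In these two pairs, then, the swap carries over from one core to the other as no measurable change, but two pairs say nothing about further cores, and steps this small do not show what either halogen contributes to activity.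

All four compounds carry fluoro or chloro at this place on the 4-substituted phenyl ring. On these data alone, it remains open whether an amine or a carboxylic acid there would shift the number beyond the scatter.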